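The source may hold more compounds than are shown below. What is called first, only, known or untested is meant among the compounds shown, and "the series" means these compounds.

Working notes on the imine series. In a functional assay on cells (Homo sapiens) for cytotoxicity, read by MTT assay, with a stated time of 24 h (a higher number here means a weaker inhibitor, a lower number a stronger inhibitor), compound 1 `CCCCCCCCCCCCCCNC(=O)[C@H](CO)/N=C/c1ccccc1[N+](=O)[O-]` gives 21700 nM. Compound 2 `CCCCCCCCCCCCCCNC(=O)[C@H](CO)/N=C/c1ccccc1OC` gives 12500 nM in this assay, and compound 3 `CCCCCCCCCCCCCCNC(=O)[C@H](CO)/N=C/c1cccc(Cl)c1` gives 24100 nM. The value of compound 1 lies within the scatter of both others: the closer comparison is a 1.1-fold higher number from compound 1 to compound 3 (0.05 log units; within the scatter), the wider one a 1.7-fold lower number from compound 1 to compound 2 (0.24 log units; within the scatter), and the remaining comparison, a 1.9-fold higher number from compound 2 to compound 3 (0.29 log units; within the scatter), also stays within the scatter. Three different substituted phenyls on the shared core thus give numbers that cannot be told apart in this assay.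

Compound 4 `CCCCCCCCCCCCCCNC(=O)[C@H](CO)/N=C/c1ccc([N+](=O)[O-])cc1` has not yet been measured. It differs from compound 1 by 4-nitrophenyl in place of 2-nitrophenyl on a carbon with a double bond to nitrogen. Going by the values given here, no measured step exchanges one nitrophenyl for another; the steps that bear on it are the two exchanges of the whole phenyl substituent from compound 1, a 1.7-fold lower number from compound 1 to compound 2 (0.24 log units; within the scatter) and a 1.1-fold higher number from compound 1 to compound 3 (0.05 log units; within the scatter), neither of which left the scatter. Among the compounds with values here, the expectation is therefore no step beyond the scatter in this assay, with a wide range kept open, as the exact rearrangement has no precedent in the measured set. Compound 4 is expected to give 20000 nM in this assay, estimated between 9000 nM and 45000 nM, which means an expected step of a 1.1-fold lower number from compound 1 to compound 4 (0.04 log units; within the scatter).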

Compound 4, half-maximal inhibitory concentration: 217000 nM
Estimate against measurement, compound 4: 11-fold (1.04 log units) below, and the stated range ends below it.
By their numbers in this assay, from the lowest: compounds 2, 1 and 3 (each within the scatter of the next); then compound 4.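

Going by these compounds alone, the position on the carbon with a double bond to nitrogen is not indifferent to the phenyl group it carries: in this assay the rearrangement of one nitrophenyl into the other (a 10-fold higher number from compound 1 to compound 4 (1.00 log units; beyond the scatter)) changes no atom count, yet it is the first step to leave the scatter. Compound 4 also stands apart from the other two compounds (a 9.0-fold higher number from compound 3 to compound 4 (0.95 log units; beyond the scatter); a 17-fold higher number from compound 2 to compound 4 (1.24 log units; beyond the scatter)), which makes it the weakest of the four, while compounds 1, 2 and 3 remain indistinguishable, so a change of phenyl group on the shared core does not by itself predict a change in this number. No supporting data are available to account for this step.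

The compounds shown do not separate the nitro group from its placement, as 4-nitrophenyl is the only group of its kind here, and an aminophenyl or a carboxyphenyl at the same position would test whether the step is specific to nitro. Going by these compounds, it also remains open whether the step persists with a chain shorter than the tetradecyl chain on the amide.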